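The source may hold more compounds than are shown below. What is called first, only, known or untested is meant among the compounds shown, and "the series" means these compounds.

Measured so far:
compound 1 `O=C(O)Cc1sc(C(c2ccc(F)cc2)c2ccc(F)cc2)nc1-c1ccc(Cl)cc1` — 80%
compound 2 `N#Cc1ccc(-c2nc(C(c3ccc(F)cc3)c3ccc(F)cc3)sc2CC(=O)O)cc1` — 30%
compound 3 `O=C(O)Cc1sc(C(c2ccc(F)cc2)c2ccc(F)cc2)nc1-c1ccco1` — 80%

In an in vitro functional assay on HEK285-7 cells for antagonist activity at prostaglandin D2 receptor 2 (Homo sapiens), read by BRET and beta-arrestin recruitment (on this read-out higher numbers stand for larger maximal responses and lower numbers for smaller maximal responses), compound 3 gives 80%, level with compound 1 and together the highest of the three numbers; the step of no change at the digits printed from compound 1 to compound 3 (within the scatter) stays within the scatter, whereas a number 50 percentage points higher from compound 2 to compound 3 (beyond the scatter) is large. Compound 4 `N#Cc1cc(-c2nc(C(c3ccc(F)cc3)c3ccc(F)cc3)sc2CC(=O)O)ccc1F` differs from compound 3 by 3-cyano-4-fluorophenyl in place of furan-2-yl on an aromatic carbon. The step that bears on this is a number 50 percentage points lower from compound 1 to compound 2 (beyond the scatter), a large fall when a cyano group enters on an aromatic carbon; compound 4 also carries a cyano group, here as 3-cyano-4-fluorophenyl, so a drop beyond the scatter is expected, though the added fluorine leaves its full size uncertain. Compound 4 is therefore estimated at 45% (range 25% to 70%). This expectation corresponds to the step of a number 35 percentage points lower from compound 3 to compound 4 (beyond the scatter).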

Compound 4, largest response reached (reported as efficacy), in percent of the reference or control that the assay uses: 80%
Compound 4: the middle estimate sits 35 percentage points below what was measured; measured number above the stated range.
By their numbers in this assay, from the lowest: compound 2; then compounds 1, 3 and 4 (each within the scatter of the next).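

In this assay, the place next to the ring nitrogen accepts 3-cyano-4-fluorophenyl with no change at the digits printed from compound 3 to compound 4 (within the scatter) and with no change at the digits printed from compound 1 to compound 4 (within the scatter) as well, so a nitrile on the phenyl ring does not by itself give the low number of compound 2. The change from 4-cyanophenyl to 3-cyano-4-fluorophenyl gives a number 50 percentage points higher from compound 2 to compound 4 (beyond the scatter) in this series. No data shown here explain this difference. From the compounds shown here alone, whether 3-cyanophenyl without the fluorine stands with compound 4 or with compound 2 remains open, as does the response with an amine on the phenyl ring.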